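Swapping methoxy for bromo on compound 1

This account rests on a few compounds, and the source may have more. Where it says the series, first, only, none or still open, it means among the compounds named here.

Compound 1 `COc1ccc(S(=O)(=O)NC(C2=CC(=O)c3c(O)ccc(O)c3C2=O)C(C)C)cc1`: 8950 nM
Compound 2 `COc1ccc(S(=O)(=O)NC(C2=CC(=O)c3c(O)ccc(O)c3C2=O)C(C)C)c(OC)c1`: 2750 nM

Among the compounds with values here, in a functional assay on HeLa cells (Homo sapiens) for cytotoxicity, read by sulforhodamine B assay (on this read-out higher numbers stand for weaker inhibition and lower numbers for stronger inhibition), compound 1 gives 8950 nM, the higher of the two numbers so far, which makes it the weaker of the pair. Compound 3 `CC(C)C(NS(=O)(=O)c1ccc(Br)cc1)C1=CC(=O)c2c(O)ccc(O)c2C1=O`, not yet measured, keeps the core of compound 1 and changes one group: bromo in place of methoxy on an aromatic carbon. In words, bromo takes the place of methoxy on an aromatic carbon, para to a large group. Within the data shown here, only one measured step offers any guide: a 3.3-fold lower number from compound 1 to compound 2 (0.51 log units; beyond the scatter), a modest change where methoxy replaced hydrogen on an aromatic carbon. That step does not involve bromo, so it is a loose guide. A step no larger than that one is therefore expected, leaning slightly towards a lower number, and it may stay within the scatter. Compound 3 is estimated at 6000 nM, with an expected range of 2200 nM to 15000 nM. The estimated change is a 1.5-fold lower number from compound 1 to compound 3 (0.17 log units; within the scatter).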

Compound 3, half-maximal inhibitory concentration: 7650 nM
Beside the measured number, compound 3's estimate is 1.3-fold (0.11 log units) below it, within the range that was stated.
By their numbers in this assay, from the lowest: compound 2; then compounds 3 and 1 (each within the scatter of the next).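

In this assay, bromo in place of methoxy at this position, para to a large group, gives a 1.2-fold lower number from compound 1 to compound 3 (0.07 log units; within the scatter), so this assay does not separate the two groups here. The swap of 2,4-dimethoxyphenyl for 4-bromophenyl gives a 2.8-fold higher number from compound 2 to compound 3 (0.44 log units; beyond the scatter), which reverses the direction of a 3.3-fold lower number from compound 1 to compound 2 (0.51 log units; beyond the scatter) and leaves compound 2 as the only one of the three set apart from the others by steps beyond the scatter. No measurement is available to explain these numbers.

As far as these compounds go, whether an amine or a carboxylic acid on this same aromatic carbon would give a step beyond the scatter remains open. From the compounds shown here alone, it is also open whether the second methoxy of compound 2 would give a similar step alongside bromo.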